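The compounds below may be only part of what the source reports. "The series", "measured", "known", "first", "only" and "open" are said of these compounds alone.

Measured so far:
- compound 1 `Cc1cc(C)c2cc(C#N)c(NCCCNC(=O)c3ccncc3)nc2c1`: 13200 nM
- compound 2 `Cc1cc(C)c2cc(C#N)c(NCCCNC(=O)c3ccccn3)nc2c1`: 100000 nM

In an assay on cells with Cystic fibrosis transmembrane conductance regulator variant F508del (Homo sapiens) as the target, read by fluorescence, with stated times of 24 h and 30 min (a lower number here means that less compound is needed, a higher number that more compound is needed for the effect), compound 1 gives 13200 nM, and in this assay compound 2 gives 100000 nM. Within the data shown here, compound 2 therefore stands at the highest of the two numbers known, and its nearest neighbour is compound 1. Among the measured compounds shown here, the one measured step joins these two: a 7.6-fold higher number from compound 1 to compound 2 (0.88 log units; beyond the scatter). Compound 3 `COc1ccccc1C(=O)NCCCNc1nc2cc(C)cc(C)c2cc1C#N` differs from compound 2 in the same place on the shared core: 2-methoxyphenyl in place of pyridin-2-yl on a carbonyl carbon. For the measured compounds named here, no measured step covers this exchange; the single known step only shows that moving the ring nitrogen from one position to another on that ring shifted the number beyond the scatter, so changes at this position can matter. Because the number for compound 2 is 100000 nM, there is little room for a larger number, so the step is expected to be flat or downward; the expected step is a 2.9-fold lower number from compound 2 to compound 3 (0.46 log units; beyond the scatter). For compound 3 the estimate in this assay is 35000 nM, with a range from 8000 nM to 100000 nM.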

Compound 3, half-maximal effective concentration: 100000 nM
The estimate for compound 3 lay 2.9-fold (0.46 log units) below the measured number; measured number inside the range.
By their numbers in this assay, from the lowest: compound 1; then compounds 2 and 3 (each within the scatter of the next).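

In this assay, the exchange of pyridin-2-yl for 2-methoxyphenyl on the carbonyl carbon gives no change at the digits printed from compound 2 to compound 3 (within the scatter), so at this position a ring of carbon only, carrying a methoxy group, cannot be told apart from a ring with one nitrogen. Among these compounds, the exchange of pyridin-4-yl for the same group gives a 7.6-fold higher number from compound 1 to compound 3 (0.88 log units; beyond the scatter), which leaves compound 1, at 13200 nM, as the only one of the three set apart from the others, and shows that the pyridin-2-yl of compound 2 is not the only group at this position to give a number beyond the scatter from that of compound 1. No measurement shown here offers an explanation for these results.

The compounds shown leave open whether the number of compound 1 depends on the pyridin-4-yl group specifically, something that pyridin-3-yl or a plain phenyl at the same place would help to settle. Going by these compounds, it also remains open whether a group of a different kind on the carbonyl carbon, such as a piperidine ring with its amine or a ring carrying a carboxylic acid, would give a number lower than that of compound 1.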